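The source may report more compounds than this note shows. Statements on the series, on what has been measured and on what is new or still open speak of the compounds shown alone.

Compound 1 `N#Cc1cncc(N2CC[C@H]3CN[C@H]3C2)c1`: in a functional assay on HEK293 cells for agonist activity at Neuronal acetylcholine receptor; alpha4/beta2 (Homo sapiens), read by FLIPR (a higher number here means that more compound is needed for the effect, a lower number that less compound is needed), compound 1 gives 1900 nM.
Compound 2 `N#Cc1cncc(N2CC[C@@H]3CN[C@@H]3C2)c1`: compound 2 gives 1900 nM.
Compound 3 `COc1ccc(N2CC[C@@H]3CN[C@@H]3C2)cn1`: compound 3 gives 4980 nM.

Compound 2 stands level with compound 1 at the digits shown, and the two together hold the lowest numbers of the three; the number for compound 3 lies beyond the scatter above them. Among the measured compounds shown here, the only measured step, no change at the digits printed from compound 1 to compound 2 (within the scatter), concerns configuration alone, as the fact that compounds 1 and 2 differ only in the configuration as drawn makes plain, so it says nothing about exchanging a group on the aromatic ring. Compound 4 `N/C(=N/O)c1cncc(N2CC[C@@H]3CN[C@@H]3C2)c1` differs from compound 2 in a group of 4 heavy atoms (1 carbon, 2 nitrogen, 1 oxygen; no ring) in place of a group of 2 heavy atoms (1 carbon, 1 nitrogen; no ring), on an aromatic carbon. For the measured compounds named here, no measured step covers a change of this kind. Going by the values given here, what compound 2 and compound 3 show together is only that a different group on the aromatic carbon can shift the number beyond the scatter. With the cyano replaced by a larger group carrying two hydrogen-bond donors, a rise of the number in this assay is expected, of modest size, with a wide range. Compound 4 is therefore expected to give 4000 nM, between 1000 nM and 16000 nM. The expected step is a 2.1-fold higher number from compound 2 to compound 4 (0.32 log units; beyond the scatter).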

Compound 4, half-maximal effective concentration: 180 nM
Estimate against measurement, compound 4: 22-fold (1.35 log units) above, outside the stated range (below it).
By their numbers in this assay, from the lowest: compound 4; then compounds 1 and 2 (each within the scatter of the next); then compound 3.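

In this assay, the aromatic carbon two atoms from the ring nitrogen proves to be a place where a single exchange can move the number strongly downward: replacing cyano with the group of 4 heavy atoms gives an 11-fold lower number from compound 2 to compound 4 (1.02 log units; beyond the scatter). Among the compounds shown here, the only earlier step concerned configuration, so this is the first measured step for a change of group here, and it shows that a larger group with 2 hydrogen-bond donors and 2 hydrogen-bond acceptors can sit at this position with a lower number as the result. No measurement shown explains which feature of the entering group accounts for this step.

As far as these compounds go, it remains open whether a carboxamide, a carboxylic acid or an aminomethyl group at this position would also lower the number. Also open, from the compounds shown here alone, is whether the same exchange on compound 1, the mirror image of compound 2, would give a step of similar size.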